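The source may hold more compounds than are shown below. What is called first, only, known or untested is meant among the compounds shown, and "the series" means these compounds.

Compound 1 (`Cc1nc([N+](=O)[O-])cn1CC(=O)Nc1ccc(F)cc1`) gives 828000 nM in this test
Compound 2 (`Cc1nc([N+](=O)[O-])cn1S(=O)(=O)c1ccc([N+](=O)[O-])cc1`) gives 611000 nM in this test
Compound 3 (`Cc1nc([N+](=O)[O-])cn1S(=O)(=O)c1ccc(F)cc1`) gives 813000 nM in this test

All three were read in an ADME assay on MDCK cells (Canis lupus familiaris) for cytotoxicity, read by MTT assay, with a stated time of 72 h (a lower number here means that less compound is tolerated, a higher number that more compound is tolerated), and compound 1 has the highest number of the three, yet its value lies within the usual scatter of both others. On these numbers, compound 1 therefore stands level with compound 2 and compound 3.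

Compound 4 (`Cc1nc([N+](=O)[O-])cn1CC(=O)Nc1ccc(C#N)cc1`) keeps the core of compound 1 and alters one group: cyano in place of fluoro on an aromatic carbon, para to a large group (cyano in place of fluoro on an aromatic carbon). Among the compounds with values here, no measured pair makes this exact exchange, and no measured compound here carries cyano. The closest evidence is a single swap on a different core. With only a 1.3-fold higher number from compound 2 to compound 3 (0.12 log units; within the scatter) to go on, for fluoro in place of nitro on an aromatic carbon, no step beyond the scatter is expected in this assay for this change, and no firm direction can be set. One pair is thin support, so the range stays wide. The step expected is a 1.2-fold lower number from compound 1 to compound 4 (0.06 log units; within the scatter) and should not be told apart from noise. For compound 4 the estimated value is 720000 nM with an expected range of 400000 nM to 1300000 nM across repeat measurements.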

Compound 4, half-maximal cytotoxic concentration: 672000 nM
Compound 4: the middle estimate sits 1.1-fold (0.03 log units) above what was measured; the range from low to high includes it.
By their numbers in this assay, from the lowest: compounds 2, 4, 3 and 1 (each within the scatter of the next).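

In this assay, putting cyano in place of fluoro on an aromatic carbon, para to a large group, gives a 1.2-fold lower number from compound 1 to compound 4 (0.09 log units; within the scatter), so on the core of compound 1 this exchange cannot be told apart from the ordinary spread of repeat measurements. Within the data shown here, until now, the only single swap on an aromatic carbon was fluoro in place of nitro on a different core, which gave a 1.3-fold higher number from compound 2 to compound 3 (0.12 log units; within the scatter), and this result adds a direct reading at this position on the core of compound 1, where the nitrile also stays within the scatter. No supporting measurement is available to explain why the number holds steady through this swap.

Still open, as far as these compounds go, is whether a quite different group at this position, such as an amine, a carboxylic acid or a longer chain, would also stay within the scatter of compound 1 or would shift the number clearly. It is also unknown whether cyano in place of fluoro would behave the same way on the core of compound 3, since this single pair speaks only for the core of compound 1.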